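Removing a Methoxy Group from a Chromone Ester Series

The source may hold more compounds than are shown below. What is called first, only, known or untested is meant among the compounds shown, and "the series" means these compounds.

Three compounds sharing one core were tested in an ADME assay on cells (T-cell, Mus musculus, strain BALB/c) for cytotoxicity, read by MTT assay, with a stated time of 48 h; on this read-out higher numbers stand for lower toxicity in this test and lower numbers for higher toxicity in this test. Compound 1 `COC(=O)c1ccc(C)cc1OC(=O)COc1cc(O)c2c(=O)cc(-c3ccccc3)oc2c1` gives 250000 nM. Compound 2 `COC(=O)c1cccc(OC)c1OC(=O)COc1cc(O)c2c(=O)cc(-c3ccccc3)oc2c1` gives 196000 nM. Compound 3 `COC(=O)c1c(Cl)cc(Cl)cc1OC(=O)COc1cc(O)c2c(=O)cc(-c3ccccc3)oc2c1` gives 345000 nM. The three numbers lie close together: compound 2 has the smallest of them, yet its gap to compound 1 and its gap to compound 3 both fall within the usual scatter of this assay, so no real difference between the three can be claimed.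

Compound 4 `COC(=O)c1ccccc1OC(=O)COc1cc(O)c2c(=O)cc(-c3ccccc3)oc2c1` has not yet been measured. It differs from compound 2 in one place: hydrogen in place of methoxy on an aromatic carbon. Since changing the substituents on this outer ring has left the numbers of compounds 1, 2 and 3 within the scatter of one another, the step from compound 2 to compound 4 is expected to be small, with no clear direction beyond the scatter, as the estimated step of a 1.2-fold higher number from compound 2 to compound 4 (0.07 log units; within the scatter) shows. On that basis compound 4 is estimated to give about 230000 nM in this assay, within a range from 120000 nM to 450000 nM.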

Compound 4, half-maximal cytotoxic concentration: 265000 nM
The estimate for compound 4 lay 1.2-fold (0.06 log units) below the measured number; the measured number falls inside the stated range.
By their numbers in this assay, from the lowest: compounds 2, 1, 4 and 3 (each within the scatter of the next).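

Taking the methoxy away leaves hydrogen on that aromatic carbon, and in this assay the step of a 1.4-fold higher number from compound 2 to compound 4 (0.13 log units; within the scatter) is the first in this set that can be read across a single change. Hydrogen in place of methyl on an aromatic carbon gives a 1.1-fold higher number from compound 1 to compound 4 (0.03 log units; within the scatter) as well, so neither methoxy nor methyl can be told apart from hydrogen in this test. Nothing measured here speaks to what lies behind these small steps.

Going by these compounds, whether a group of another kind on this carbon, such as an amine, a carboxylic acid or a longer chain, would move the number beyond the scatter stays open. So does whether replacing the methoxycarbonyl group itself would change the picture.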